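Amide substituent change from compound 1 to compound 3

The compounds below may be only part of what the source reports. "The series", "measured", "known", "first", "only" and "open" are said of these compounds alone.

Measured compounds:
compound 1, `CCn1c(C(=O)NCCCN(C)C)ccc1C(CC)(CC)c1ccc(OCCC(O)(CC)CC)c(C)c1`, 2420 nM
compound 2, `CCn1c(C(=O)NCCN)ccc1C(CC)(CC)c1ccc(OCCC(O)(CC)CC)c(C)c1`, 2940 nM

In an ADME assay on L02 cells (Homo sapiens) for antiproliferative activity, read by MTT assay, with a stated time of 48 h (on this read-out higher numbers stand for weaker inhibition and lower numbers for stronger inhibition), compound 1 gives 2420 nM and compound 2 gives 2940 nM. Compound 1 carries the smaller of the two numbers, but the step of a 1.2-fold higher number from compound 1 to compound 2 (0.08 log units; within the scatter) is within the scatter, so the two compounds are not told apart.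

Compound 3, `CCn1c(C(=O)Nc2cccc(C(F)(F)F)c2)ccc1C(CC)(CC)c1ccc(OCCC(O)(CC)CC)c(C)c1`, differs from compound 1 by 3-(trifluoromethyl)phenyl in place of 3-(dimethylamino)propyl on an amide-type nitrogen. Going by the values given here, the only measured step, from compound 1 to compound 2, alters the end of the same chain and stays within the scatter; it does not bear on exchanging the whole chain for an aromatic ring. Among the compounds with values here, no measured step therefore supports a direction for compound 3, and the expected step of a 1.2-fold lower number from compound 1 to compound 3 (0.08 log units; within the scatter) is set near zero with a wide range. Compound 3 is expected to give 2000 nM, between 500 nM and 8000 nM.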

Compound 3, half-maximal inhibitory concentration: > 50000 nM
Compound 3: no number, only a limit; the forecaster's own chance of this, stated with the estimate: 10%; middle value at least 25-fold (1.39 log units) away from the limit.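

In this assay compound 3 reads as a limit of the assay and not as a number: the limit of > 50000 nM in this assay, at which 1 of the 3 values shown sits.

Exchanging the whole substituent on the amide-type nitrogen moves the read-out sharply, with an at least 20-fold higher number from compound 1 to compound 3 (1.31 log units; beyond the scatter) and an at least 17-fold higher number from compound 2 to compound 3 (1.23 log units; beyond the scatter), whereas the change at the chain end gave only a 1.2-fold higher number from compound 1 to compound 2 (0.08 log units; within the scatter). The position is therefore not indifferent to what it carries: 3-(trifluoromethyl)phenyl gives much weaker inhibition here than either 3-(dimethylamino)propyl or 2-aminoethyl.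

The change swaps the amine-bearing chain for an aromatic ring and adds trifluoromethyl in one step, so these contributions cannot be separated. An unsubstituted phenyl, a 3-aminophenyl or a benzyl group on the same nitrogen would be the comparisons that could divide them.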